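The source may hold more compounds than are shown below. What is called first, only, known or untested is meant among the compounds shown, and "the series" means these compounds.

In an assay on isolated protein for inhibition of Maltase-glucoamylase (Homo sapiens), with a stated time of 15 min (a lower number here means a stronger inhibitor, a higher number a weaker inhibitor), three compounds built on one shared core have been measured. Compound 1 `COc1ccc(O)c(/C=N/NC(=O)c2ccc(-c3nc4ccccc4s3)cc2)c1` gives 6500 nM, compound 2 `COc1ccc(/C=N/NC(=O)c2ccc(-c3nc4ccccc4s3)cc2)c(O)c1` gives 6970 nM, and compound 3 `O=C(N/N=C/c1ccccc1)c1ccc(-c2nc3ccccc3s2)cc1` gives 8050 nM. Compound 3 has the highest of the three numbers, but its steps from the other two, a 1.2-fold higher number from compound 1 to compound 3 (0.09 log units; within the scatter) and a 1.2-fold higher number from compound 2 to compound 3 (0.06 log units; within the scatter), are both within the scatter, so no order among the three can be claimed. The step of a 1.1-fold higher number from compound 1 to compound 2 (0.03 log units; within the scatter) is within the scatter as well.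

Compound 4 `COc1ccc(/C=N/NC(=O)c2ccc(-c3nc4ccccc4s3)cc2)c(I)c1O` has not yet been measured. It differs from compound 3 in one place: 3-hydroxy-2-iodo-4-methoxyphenyl in place of phenyl on a carbon with a double bond to nitrogen. The measured steps that bear on this are the two leading into compound 3: each put plain phenyl in place of a phenyl bearing a hydroxy and a methoxy group, and neither moved the number beyond the scatter. Going by the values given here, the ring entering compound 4 carries its hydroxy and methoxy groups in a new arrangement together with an iodine, and for that combination no measured step exists. A step of little size is therefore expected in this assay, if anything toward a lower number. Compound 4 is estimated at 6500 nM, within a range from 3000 nM to 14000 nM. This corresponds to an expected step of a 1.2-fold lower number from compound 3 to compound 4 (0.09 log units; within the scatter).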

Compound 4, half-maximal inhibitory concentration: 44800 nM
Beside the measured number, compound 4's estimate is 6.9-fold (0.84 log units) below it; measured number outside the range, above it.
By their numbers in this assay, from the lowest: compounds 1, 2 and 3 (each within the scatter of the next); then compound 4.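

In this assay the ring on the carbon with a double bond to nitrogen now shows a change beyond the scatter, with 3-hydroxy-2-iodo-4-methoxyphenyl giving the weakest inhibitor of the four against each of the other rings (a 5.6-fold higher number from compound 3 to compound 4 (0.75 log units; beyond the scatter); a 6.4-fold higher number from compound 2 to compound 4 (0.81 log units; beyond the scatter); a 6.9-fold higher number from compound 1 to compound 4 (0.84 log units; beyond the scatter)). The earlier swaps among phenyl and the two rings bearing a hydroxy and a methoxy group stayed within the scatter, so they made this place look tolerant, whereas compound 4 shows that it does not accept every ring equally. Nothing among the available data explains the rise in the number.

The entering ring brings an iodine and a new arrangement of the hydroxy and methoxy groups at once, so the compounds shown cannot say whether the iodine, the arrangement or the two together lie behind the weaker inhibition, and the same ring without the iodine, or a phenyl carrying only an iodine, would separate them. Going by these compounds, whether a ring carrying an amine or a carboxylic acid at this place would give a lower number than the group of compounds 1, 2 and 3 also stays open.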